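The source may hold more compounds than are shown below. What is called first, only, known or untested is meant among the compounds shown, and "the series" means these compounds.

- Compound 1 `CNC(=O)/C=C/c1ccncc1-c1ccc2ccccc2c1`: 8680 nM
- Compound 2 `NNC(=O)CCc1ccncc1-c1ccc2ccccc2c1`: > 10000 nM (a limit of the assay, not a number)
- Compound 3 `CNC(=O)CCc1ccncc1-c1ccc2ccccc2c1`: 8980 nM

In a functional assay on MDA-MB-231 cells (Homo sapiens) for inhibition, read by sulforhodamine B assay, with a stated time of 72 h (on this read-out higher numbers stand for weaker inhibition of growth and lower numbers for stronger inhibition of growth), compound 3 gives 8980 nM, level within the scatter with compound 1 at 8680 nM.

Compound 4 `COC(=O)/C=C/c1ccncc1-c1ccc2ccccc2c1` differs from compound 3 as follows: 2-(methoxycarbonyl)ethenyl in place of 2-(methylcarbamoyl)ethyl on an aromatic carbon. The ethenyl link alone moved little in a 1.0-fold higher number from compound 1 to compound 3 (0.01 log units; within the scatter), which lies within the scatter. The change on the amide-type nitrogen, an at least 1.1-fold lower number from compound 2 to compound 3 (0.04 log units; that floor lies within the scatter), has a floor that also lies within the scatter. Within the data shown here, no measured step replaces the amide with an ester, so that part of the change remains open. The expected size of the change is therefore small, with no clear direction: a 1.3-fold lower number from compound 3 to compound 4 (0.11 log units; within the scatter). For compound 4 the estimated value is 7000 nM, with an expected range of 2500 nM to 15000 nM.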

Compound 4, concentration for 50% growth inhibition: 4710 nM
Beside the measured number, compound 4's estimate is 1.5-fold (0.17 log units) above it, within the range that was stated.
By their numbers in this assay, from the lowest: compounds 4, 1 and 3 (each within the scatter of the next). At a limit, above all of these: compound 2.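

At this position, replacing the amide with an ester gives only small shifts in this assay: methoxy in place of methylamino on the carbonyl carbon gives a 1.8-fold lower number from compound 1 to compound 4 (0.27 log units; within the scatter), and the full side-chain swap gives a 1.9-fold lower number from compound 3 to compound 4 (0.28 log units; within the scatter). Among these compounds, the one step past the scatter is an at least 2.1-fold lower number from compound 2 to compound 4 (0.32 log units; beyond the scatter). Compound 2 gives a limit of the assay, not a number: the limit of > 10000 nM in this assay, at which 1 of the 4 values shown sits.

Going by these compounds, it remains open how a carboxylic acid or a longer chain would read in this place. On these data alone, it is also open whether a saturated 2-(methoxycarbonyl)ethyl chain would read like the ethenyl ester of compound 4.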